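The source may report more compounds than this note shows. Statements on the series, on what has been measured and on what is new or still open speak of the compounds shown alone.

Within the data shown here, compound 1, `O=C(Nc1ccc(-c2noc(-c3cccc(NS(=O)(=O)c4ccc(C(F)(F)F)cc4)c3)n2)c(Cl)c1)c1cccnc1`, is the first of two measured compounds here. In a functional assay on MDA-MB-231 cells (Homo sapiens) for antiproliferative activity, read by MTT assay, with a stated time of 72 h (a higher number here means a weaker inhibitor, a lower number a stronger inhibitor), compound 1 reaches only the limit of the assay, > 10000 nM. Compound 2, `O=C(Nc1ccc(Cl)cc1)Nc1cccc(-c2nc(-c3ccc(NC(=O)c4cccnc4)cc3Cl)no2)c1`, is the second, and in this assay compound 2 likewise reaches only a limit, > 10000 nM. Where compound 2 stands is therefore defined by the limit of > 10000 nM in this assay, at which 2 of the 2 values shown sit; no number separates the two measured compounds, and no step between them can be sized.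

Compound 3, `CC(=O)Nc1ccc(NC(=O)Nc2cccc(-c3nc(-c4ccc(NC(=O)c5cccnc5)cc4Cl)no3)c2)cc1Cl`, differs from compound 2 in one place: 4-acetamido-3-chlorophenyl in place of 4-chlorophenyl on an amide-type nitrogen. Among the measured compounds shown here, with no measured step to lean on, the account expects the step that the limit leaves unreadable from compound 2 to compound 3 to stay within the scatter, most likely leaving compound 3 at a limit again. On that basis compound 3 is estimated at 15000 nM in this assay, within a range from 3000 nM to 60000 nM.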

Compound 3, half-maximal inhibitory concentration: > 10000 nM
Compound 3: a limit, no number (the forecaster's own chance of this, stated with the estimate: 70%); the middle value lies beyond the limit too.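

Compound 2 and compound 3 both give only a limit, not a number, so no step can be read between them: the limit of > 10000 nM in this assay, at which 3 of the 3 values shown sit. The compounds shown leave open whether the change to 4-acetamido-3-chlorophenyl alters activity in this assay, since none gives a number there.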